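Compound 2 to compound 3: a change on sulfonyl sulfur

The source may hold more compounds than are shown below. What is called first, only, known or untested is meant among the compounds shown, and "the series" means these compounds.

Within the data shown here, in an in vitro ADME assay on microsomes from liver (Rattus norvegicus) for metabolic stability, read by LC-MS, tested at 1 uM (on this read-out higher numbers stand for fast clearance and lower numbers for slow clearance), compound 2 `COCCN(C)S(=O)(=O)c1ccc(C)c(C#Cc2cc(Cl)ccc2OCC(=O)O)c1` gives 49 mL.min-1.g-1, the only actual number so far. Compound 1 `CN(C)S(=O)(=O)c1ccc(F)c(C#Cc2cc(Cl)ccc2OCC(=O)O)c1` reads < 10 mL.min-1.g-1, which is a limit of the assay and not a number. The next compound to be tested, compound 3 `Cc1ccc(S(=O)(=O)NC(C)C)cc1C#Cc1cc(Cl)ccc1OCC(=O)O`, keeps the shared core and the methyl group of compound 2. It carries isopropylamino in place of (2-methoxyethyl)(methyl)amino on a sulfonyl sulfur. Among the measured compounds shown here, no measured pair isolates this change, so the expectation starts from compound 2 at 49 mL.min-1.g-1 and remains uncertain. A small step towards slower clearance is expected a 1.5-fold lower number from compound 2 to compound 3 (0.19 log units; within the scatter), one that would not clearly exceed the scatter of this assay. For compound 3 the estimated value is 32 mL.min-1.g-1, with an expected range from 13 mL.min-1.g-1 to 75 mL.min-1.g-1.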

Compound 3, intrinsic clearance in microsomes: 12 mL.min-1.g-1
The estimate for compound 3 lay 2.7-fold (0.43 log units) above the measured number, and the stated range ends above it.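

In this assay, the change on the sulfonyl sulfur gives a 4.1-fold lower number from compound 2 to compound 3 (0.61 log units; beyond the scatter), with the methyl group and the shared core held constant. Among these compounds, this is the first pair that differs in one place, and it shows that the group on this sulfur can move clearance beyond the scatter. The change is a single swap, however: isopropylamino has fewer heavy atoms than (2-methoxyethyl)(methyl)amino, lacks its ether oxygen and brings a hydrogen-bond donor, and this pair cannot separate these differences.

On these data alone, compound 1 reads < 10 mL.min-1.g-1, which is a limit of the assay and not a number, so steps involving it cannot be read, and the read-out has a floor: the limit of < 10 mL.min-1.g-1 in this assay, at which 1 of the 3 values shown sits. It remains open whether isopropyl(methyl)amino, which keeps the isopropyl group but has no hydrogen on the sulfonamide nitrogen, would read like compound 3 or like compound 2.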